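Swapping pyridin-2-yl for 3-hydroxyphenyl in compound 3

The compounds below may be only part of what the source reports. "The series", "measured", "known", "first", "only" and "open" are said of these compounds alone.

- compound 1 `Cn1ncc2c(=O)n(-c3ccccc3)c(SCc3cccc(F)c3)cc21`: 178000 nM
- compound 2 `Cn1ccc2c(=O)n(-c3ccccc3)c(SCc3cccc(F)c3)nc21`: 23000 nM
- compound 3 `CC(Sc1nc2c(cnn2C)c(=O)n1-c1ccccc1)c1ccccn1`: 20000 nM

All three compounds were measured in a physicochemical assay for solubility, using the shake flask method, in phosphate buffer, with a stated time of 24 h, at pH 7.4; a lower number here means a less soluble compound, a higher number a more soluble compound. Compound 3, at 20000 nM, cannot be told apart from compound 2, at 23000 nM, since the two lie within the scatter of each other. Compound 1, at 178000 nM, stands clearly apart from both, on the more soluble side.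

The next compound to be measured is compound 4 `CC(Sc1nc2c(cnn2C)c(=O)n1-c1ccccc1)c1cccc(O)c1`. It has 3-hydroxyphenyl in place of pyridin-2-yl on a saturated chain carbon bound to a saturated chain carbon and a sulfur.

Among the measured compounds shown here, no two measured compounds differ in only one place, so the data do not show directly what a single change does in this assay. The best reference is compound 3 at 20000 nM, which differs from compound 4 only in this group. No step beyond the scatter is expected, and the estimated step of a 1.4-fold lower number from compound 3 to compound 4 (0.15 log units; within the scatter) leans slightly downward. For compound 4 the estimated value is 14000 nM, with an expected range of 5000 nM to 40000 nM.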

Compound 4, solubility: 21000 nM
Beside the measured number, compound 4's estimate is 1.5-fold (0.18 log units) below it; the measured number falls inside the stated range.
By their numbers in this assay, from the lowest: compounds 3, 4 and 2 (each within the scatter of the next); then compound 1.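

Among the compounds shown here, this is the first pair in the set that differs in only one place, so it gives the first direct reading of a single change in this assay: 3-hydroxyphenyl in place of pyridin-2-yl, on a saturated chain carbon bound to a saturated chain carbon and a sulfur, gives a 1.1-fold higher number from compound 3 to compound 4 (0.02 log units; within the scatter). The entering group has a ring of carbon only and 1 hydrogen-bond donor, while the leaving group has a ring with 1 hetero atom and 0 donors, yet the two compounds cannot be told apart by this read-out. No supporting measurement bears on why this is so.

Still open, on these data alone, is whether a quite different group at this place, such as an amine or a carboxylic acid, would also leave the number unmoved. A single pair also cannot show whether this swap would read the same on another core.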